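Swapping Trifluoromethyl for Benzyl on the Sulfonyl Sulfur

A few compounds are considered here, and "the series" means these few. Any claim that something is new, unique, unknown or untested is made for them only; others in the source may bear on it.

Measured in a functional assay for antagonist activity at Vanilloid receptor (Rattus norvegicus); on this read-out lower numbers stand for stronger inhibition and higher numbers for weaker inhibition:
Compound 1 `CC(C)(C)c1ccc(C/N=C(\S)NCc2ccc(OS(C)(=O)=O)cc2)cc1` gives 9300 nM.
Compound 2 `CC(C)(C)c1ccc(C/N=C(\S)NCc2ccc(NS(=O)(=O)C(F)(F)F)cc2)cc1` gives 12400 nM.

Compound 2 has no measured neighbour that separates from it: the step of a 1.3-fold higher number from compound 1 to compound 2 (0.12 log units; within the scatter) stays within the scatter. Compound 3 `CC(C)(C)c1ccc(C/N=C(\S)NCc2ccc(NS(=O)(=O)Cc3ccccc3)cc2)cc1` differs from compound 2 by benzyl in place of trifluoromethyl on a sulfonyl sulfur. That single measured step is the only one touching this part of the molecule, and it changed the group around the sulfonyl rather than the substituent on the sulfur itself, so nothing measured points to a shift in either direction. For compound 3 a number close to compound 2 is expected, a 1.2-fold lower number from compound 2 to compound 3 (0.09 log units; within the scatter), without a step beyond the scatter. The estimate for compound 3 is 10000 nM, within 3000 nM to 40000 nM.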

Compound 3, half-maximal inhibitory concentration: 1500 nM
Estimate against measurement, compound 3: 6.7-fold (0.82 log units) above; the measured number lies below the stated range.
By their numbers in this assay, from the lowest: compound 3; then compounds 1 and 2 (each within the scatter of the next).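

The substituent on the sulfonyl sulfur matters in this assay: with benzyl in place of trifluoromethyl, there is an 8.3-fold lower number from compound 2 to compound 3 (0.92 log units; beyond the scatter), whereas the earlier change stayed within the scatter. Going by these compounds alone, the (benzylsulfonyl)amino group also separates from the (methylsulfonyl)oxy group of the first compound, with a 6.2-fold lower number from compound 1 to compound 3 (0.79 log units; beyond the scatter), so this sulfur substituent is the first change here to shift the read-out clearly.

On these data alone, whether phenyl or phenylethyl on the sulfonyl sulfur would give a similar number remains open. Nothing available here gives a reason for the stronger inhibition.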